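Returning to a carbamate without the amide hydrogen

The compounds below may be only part of what the source reports. "The series", "measured", "known", "first", "only" and "open" are said of these compounds alone.

The measured compounds, each in an assay on DDT1 cells (Cricetulus griseus) for binding affinity to adenosine receptor A1 (Homo sapiens), read by radioligand binding; on this read-out lower numbers stand for stronger inhibition and higher numbers for weaker inhibition:
compound 1, `CCCNC(=O)OC[C@H]1OC(n2cnc3c(NC4CCOC4)ncnc32)[C@H](O)[C@@H]1O`, gives 235 nM
compound 2, `CC(C)/N=C(\S)OC[C@H]1OC(n2cnc3c(NC4CCOC4)ncnc32)[C@H](O)[C@@H]1O`, gives 36 nM
compound 3, `O[C@@H]1[C@@H](CO/C(S)=N/C2CC2)OC(n2cnc3c(NC4CCOC4)ncnc32)[C@@H]1O`, gives 157 nM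

Compound 3 stands second highest of the three numbers. Its nearest neighbour is compound 1, a 1.5-fold lower number from compound 1 to compound 3 (0.18 log units; within the scatter), a gap within the scatter, so no order between compound 1 and compound 3 can be claimed. Its furthest neighbour is compound 2, a 4.4-fold higher number from compound 2 to compound 3 (0.64 log units; beyond the scatter), a change that does lie beyond the scatter.

Compound 4, `CN(C)C(=O)OC[C@H]1OC(n2cnc3c(NC4CCOC4)ncnc32)[C@H](O)[C@@H]1O`, differs from compound 3 in one place: a group of 5 heavy atoms (3 carbon, 1 nitrogen, 1 oxygen; no ring) in place of a group of 6 heavy atoms (4 carbon, 1 nitrogen, 1 sulfur; one three-membered non-aromatic ring of carbon only), on an oxygen on a saturated carbon. Compound 4 thus carries a carbamate with a carbonyl, as compound 1 does, but with no hydrogen-bond donor and with the dimethylcarbamoyl group in place of the propyl chain of compound 1. The step that bears most on this change is a 1.5-fold lower number from compound 1 to compound 3 (0.18 log units; within the scatter), which shows that exchanging the carbamate of compound 1 for the sulfur-bearing group of compound 3 moved the number only within the scatter. Reversing that exchange while also removing the donor gives no strong reason to expect a large step in this assay in either direction; a modest rise, back toward compound 1 or a little past it, is the most likely outcome. Compound 4 is therefore expected to show a step of a 2.5-fold higher number from compound 3 to compound 4 (0.41 log units; beyond the scatter), and its estimated value is 400 nM with a range from 150 nM to 1100 nM.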

Compound 4, inhibition constant: 238 nM
The estimate for compound 4 lay 1.7-fold (0.23 log units) above the measured number; measured number inside the range.
By their numbers in this assay, from the lowest: compound 2; then compounds 3, 1 and 4 (each within the scatter of the next).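

In this assay, dimethylamino in place of propylamino on the carbonyl carbon gives a 1.0-fold higher number from compound 1 to compound 4 (0.01 log units; within the scatter), so at this oxygen the carbamate without the amide hydrogen cannot be told apart from the carbamate of compound 1. The sulfur-bearing cyclopropyl group also cannot be told apart from dimethylcarbamoyl, with a 1.5-fold higher number from compound 3 to compound 4 (0.18 log units; within the scatter), whereas the sulfur-bearing isopropyl group remains clearly separate, with a 6.6-fold higher number from compound 2 to compound 4 (0.82 log units; beyond the scatter). Across these four compounds, only compound 2 stands apart, with steps beyond the scatter to each of the other three, while compounds 1, 3 and 4 form a group in which no order can be claimed. The data shown offer no measurement that accounts for these results.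

As far as these compounds go, it remains open whether a morpholine ring or a longer chain such as butyl on the carbamate nitrogen would also leave the number unchanged. Also open, from the compounds shown here alone, is whether a tert-butyl group on the double-bonded nitrogen of the sulfur-bearing series would match compound 2 or fall back toward compound 3.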